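A Methylpiperazine Tail on the Difluorophenyl Amide

The source may report more compounds than this note shows. Statements on the series, on what has been measured and on what is new or still open speak of the compounds shown alone.

Compound 1 `COc1cc2c(Oc3ccc(NC(=O)c4nn(-c5ccccc5)c(=O)cc4C)cc3F)ccnc2cc1OCCCN1CCN(C)CC1`: 350 nM
Compound 2 `COc1cc2c(Oc3ccc(NC(=O)c4nn(-c5ccc(F)c(F)c5)c(=O)cc4C)cc3F)ccnc2cc1OCCCN1CCCC1`: 220 nM

In a functional assay on A549 cells (Homo sapiens) for inhibition, read by MTT assay, with a stated time of 72 h (on this read-out higher numbers stand for weaker inhibition and lower numbers for stronger inhibition), compound 1 gives 350 nM and compound 2 gives 220 nM. Compound 2 carries the smaller of the two numbers, yet its gap to compound 1 falls within the usual scatter, so the two cannot be told apart. Compound 1 and compound 2 also differ in two places at once, so no single step can be read from that pair.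

Compound 3 `COc1cc2c(Oc3ccc(NC(=O)c4nn(-c5ccc(F)c(F)c5)c(=O)cc4C)cc3F)ccnc2cc1OCCCN1CCN(C)CC1` differs from compound 2 in one place: 4-methylpiperazin-1-yl in place of pyrrolidin-1-yl on a saturated chain carbon, three bonds along the chain from an oxygen on an aromatic ring. The group that enters is the same amine tail found in compound 1, whose number in this assay sits within the scatter of compound 2. The step of a 1.3-fold higher number from compound 2 to compound 3 (0.10 log units; within the scatter) is therefore expected to stay within the scatter, with no clear direction. Compound 3 is estimated at 280 nM, with a range from 120 nM to 650 nM.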

Compound 3, half-maximal inhibitory concentration: 130 nM
Estimate against measurement, compound 3: 2.2-fold (0.33 log units) above; the measured number falls inside the stated range.
By their numbers in this assay, from the lowest: compounds 3, 2 and 1 (each within the scatter of the next, the first and the last beyond it).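

In this assay the exchange of pyrrolidin-1-yl for 4-methylpiperazin-1-yl gives a 1.7-fold lower number from compound 2 to compound 3 (0.23 log units; within the scatter) and so does not separate the two amine tails at this place on the chain. For the compounds shown here, compound 3 also allows the first single-place reading of the aromatic substituent: 3,4-difluorophenyl in place of phenyl on an aromatic nitrogen gives a 2.7-fold lower number from compound 1 to compound 3 (0.43 log units; beyond the scatter) as a modest step with the 4-methylpiperazin-1-yl tail held constant. No evidence is available that would account for either step.

From the compounds shown here alone, whether 3,4-difluorophenyl gives a similar step with the pyrrolidin-1-yl tail remains open. Also open, going by these compounds, is how a single fluorine or a chlorine on that phenyl, or a morpholine or a dimethylamino group on the same chain, would read in this assay here.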